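A few compounds are considered here, and "the series" means these few. Any claim that something is new, unique, unknown or untested is made for them only; others in the source may bear on it.

Measured compounds in an ADME assay on HEK293 cells (Homo sapiens) for cytotoxicity, read by reporter gene assay and resazurin assay, with a stated time of 48 h; on this read-out higher numbers stand for lower toxicity in this test and lower numbers for higher toxicity in this test:
Compound 1, `COc1c(Br)cc(Br)cc1C(=O)Nc1ccccc1`: its value, > 100000 nM, is a limit of the assay.
Compound 2, `O=C(Nc1ccc(Sc2nc3ccccc3s2)cc1)c1ccccc1O`: 74000 nM.
Compound 3, `COc1c(Br)cc(Br)cc1C(=O)Nc1cccc(Cl)c1`: its value, > 100000 nM, is a limit of the assay.

Compound 1 stands at the limit of > 100000 nM in this assay, at which 2 of the 3 values shown sit, so only a limit is known for it. For the measured compounds named here, the one measured step, a step that the two limits leave unreadable from compound 1 to compound 3, is itself unreadable, and it concerns chloro in place of hydrogen on an aromatic carbon. Compound 4, `O=C(Nc1ccccc1)c1cc(Br)cc(Br)c1O`, differs from compound 1 as follows: hydrogen in place of methyl on an oxygen on an aromatic ring. Going by the values given here, no measured step touches the methyl on oxygen, so nothing here points to a change in this assay beyond the scatter. For compound 4 a value near the limit is expected, estimated at 100000 nM within 30000 nM to 300000 nM. The step of a number no higher from compound 1 to compound 4 (the limit leaves the size open) is thus expected to be small.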

Compound 4, half-maximal cytotoxic concentration: 34000 nM
Compound 4: middle estimate off by 2.9-fold (0.47 log units), on the high side, and the stated range covers the measured number.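

In this assay, methoxy to hydroxy on the aromatic ring brings an at least 2.9-fold lower number from compound 1 to compound 4 (0.46 log units; beyond the scatter), so removing this methyl from the oxygen gives the first readable change in toxicity in this test among these compounds. The earlier chloro step cannot be read, so this oxygen is the only place shown to respond. The full size of the step stays open because only a limit is known for compound 1: the limit of > 100000 nM in this assay, at which 2 of the 4 values shown sit.

The compounds shown leave open whether an ethoxy group or an amine in place of the methoxy would also lower the number.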